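A few compounds are considered here, and "the series" means these few. Any claim that something is new, unique, unknown or untested is made for them only; others in the source may bear on it.

Working notes on the ether-lipid phosphocholine analogues.

Of the compounds shown here, three have been measured in a functional assay on HuT78 cells (Homo sapiens) for cytotoxicity, with a stated time of 24 h; on this read-out lower numbers stand for stronger inhibition and higher numbers for weaker inhibition. Compound 1, `CCCCCCCCCCCCCCCCCCOCC(COP(=O)(O)O[C@H](C)C[N+](C)(C)C)OC`, gives 9.1 ug/mL. Compound 2, `CCCCCCCCCCCCCCCCCCOCC(COP(=O)(O)O[C@@H](C)C[N+](C)(C)C)OC`, is the counterpart of compound 1 at the stereocentre; in this assay compound 2 gives 9.3 ug/mL. The step between them is a 1.0-fold higher number from compound 1 to compound 2 (0.01 log units; within the scatter); of note for that pair is the fact that one of compounds 1 and 2 is drawn with a defined configuration and the other without, at the place where they differ. Compound 3, `CCCCCCCCCCCCCCCCCCOCC(COP(=O)(O)OC[C@@H](C)[N+](C)(C)C)OC`, carries the alternative group of 7 heavy atoms (6 carbon, 1 nitrogen; no ring) on the oxygen and gives 6.9 ug/mL. Against compound 1 this is a 1.3-fold lower number from compound 1 to compound 3 (0.12 log units; within the scatter), and against compound 2 it is a 1.3-fold lower number from compound 2 to compound 3 (0.13 log units; within the scatter). Compound 3 thus holds the lowest of the three numbers, but both of its steps to the other compounds lie within the scatter, so the three cannot be ordered.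

The next compound, compound 4, is `CCCCCCCCCCCCCCCCCCOCC(COP(=O)(O)OC[C@H](C)[N+](C)(C)C)OC`. Relative to compound 3 the change is the two compounds have the same atoms and bonds; at least one stereo element is drawn with a configuration in one of them and without one in the other: 1 of 3 stereo elements differ; a stereocentre at a saturated chain carbon is drawn R in compound 3 and S in compound 4. Within the data shown here, the one measured step of the same kind, the inversion of a stereocentre at a saturated chain carbon, gave a 1.0-fold higher number from compound 1 to compound 2 (0.01 log units; within the scatter), a step within the scatter. On that basis no step beyond the scatter is expected in this assay. The expected step is a 1.0-fold higher number from compound 3 to compound 4 (0.02 log units; within the scatter). Compound 4 is therefore estimated at 7.2 ug/mL, with a range from 4 ug/mL to 13 ug/mL.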

Compound 4, concentration for 50% inhibition: 5.9 ug/mL
The estimate for compound 4 lay 1.2-fold (0.09 log units) above the measured number; the range from low to high includes it.
By their numbers in this assay, from the lowest: compounds 4, 3, 1 and 2 (each within the scatter of the next).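

With a 1.2-fold lower number from compound 3 to compound 4 (0.07 log units; within the scatter), the inversion of a stereocentre at a saturated chain carbon also stays within the scatter for the second group of 7 heavy atoms (6 carbon, 1 nitrogen; no ring) on the oxygen, matching the earlier 1.0-fold higher number from compound 1 to compound 2 (0.01 log units; within the scatter), so neither pair shows a readable preference for R or S in this assay. The exchange between the two groups on the oxygen likewise stays within the scatter for the new pairs, with a 1.5-fold lower number from compound 1 to compound 4 (0.19 log units; within the scatter) and a 1.6-fold lower number from compound 2 to compound 4 (0.20 log units; within the scatter), so neither the configuration nor the choice of group separates the four compounds. The stereo comparison carries one reservation: the fact that one of compounds 3 and 4 is drawn with a defined configuration and the other without, at the place where they differ.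

The compounds shown leave open whether this assay responds at all to changes elsewhere on the shared core, for example a longer chain in place of the present ether chain or a primary amine in place of the trimethylammonium group. They also leave open whether the lack of separation seen for these two groups on the oxygen would hold for a larger group there, such as a triethylammonium group.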